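The source may report more compounds than this note shows. Statements on the series, on what has been measured and on what is new or still open speak of the compounds shown alone.

Compound 1 `CC(C)(C)OC(=O)NCCCCCNC(=O)CN1CN(c2ccccc2)C2(CCN(C(=O)c3ccc(C(C)(C)C)cc3)CC2)C1=O` gives 13700 nM; compound 2 `CC(C)(C)c1ccc(C(=O)N2CCC3(CC2)C(=O)N(CC(=O)NCCCCCNS(C)(=O)=O)CN3c2ccccc2)cc1` gives 5500 nM; compound 3 `CC(C)(C)c1ccc(C(=O)N2CCC3(CC2)C(=O)N(CC(=O)NCCCCO)CN3c2ccccc2)cc1` gives 19200 nM.

In an assay on HEK293 cells for displacement of a labelled ligand from NPC1-like intracellular cholesterol transporter 1 (Homo sapiens) (on this read-out higher numbers stand for weaker inhibition and lower numbers for stronger inhibition), compound 3 stands highest of the three numbers, though its gap to compound 1 is within the scatter (a 1.4-fold higher number from compound 1 to compound 3 (0.15 log units; within the scatter)), while the gap to compound 2 is beyond it (a 3.5-fold higher number from compound 2 to compound 3 (0.54 log units; beyond the scatter)). Compound 4 `CC(C)(C)c1ccc(C(=O)N2CCC3(CC2)C(=O)N(CC(=O)NCNS(C)(=O)=O)CN3c2ccccc2)cc1` differs from compound 3 by methanesulfonamido in place of 3-hydroxypropyl on a saturated chain carbon bound to an amide-type nitrogen. The step that bears on this is a 3.5-fold higher number from compound 2 to compound 3 (0.54 log units; beyond the scatter), which, read backwards, brings a methanesulfonamide in and lowers the number; a 2.5-fold lower number from compound 1 to compound 2 (0.40 log units; beyond the scatter) also favoured methylsulfonyl. Among the measured compounds shown here, no measured step covers the shorter chain of compound 4, so a modest lowering is expected, a 2.4-fold lower number from compound 3 to compound 4 (0.38 log units; beyond the scatter). Compound 4 is estimated at 8000 nM, within 3000 nM to 25000 nM.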

Compound 4, half-maximal inhibitory concentration: 3200 nM
Compound 4: middle estimate off by 2.5-fold (0.40 log units), on the high side; low and high end bracket the measured number.
By their numbers in this assay, from the lowest: compounds 4 and 2 (each within the scatter of the next); then compounds 1 and 3 (each within the scatter of the next).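

Methanesulfonamido stands in place of the 4-(methanesulfonamido)butyl chain. The number stays unresolved, with a 1.7-fold lower number from compound 2 to compound 4 (0.24 log units; within the scatter), so the longer chain of compound 2 is not required for its activity here. The methanesulfonamido compound also keeps its lead over the other end groups, with a 6.0-fold lower number from compound 3 to compound 4 (0.78 log units; beyond the scatter) and a 4.3-fold lower number from compound 1 to compound 4 (0.63 log units; beyond the scatter), the first being the largest step seen so far in this set. No measured evidence accounts for these steps. The compounds shown leave open whether an amine or a carboxylic acid at this position would match methanesulfonamido, and whether a sulfonamide on a chain longer than that of compound 2 would shift the number.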